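The compounds below may be only part of what the source reports. "The series", "measured", "known", "first", "only" and "open" are said of these compounds alone.

Measured compounds in an assay on CHO cells for displacement of a labelled ligand from Alpha-1B adrenergic receptor (Homo sapiens); on this read-out lower numbers stand for stronger inhibition and higher numbers for weaker inhibition:
- Compound 1 `COc1cccc(OC)c1OCCNCCOc1ccccc1OCc1ccccc1`: 0.537 nM
- Compound 2 `COc1cccc(OC)c1OCCNCCOc1ccccc1OCc1cccc(C)c1`: 0.251 nM

Compound 1 stands at the higher of the two numbers in this assay. Going by the values given here, the only neighbour is compound 2, reached by a 2.1-fold lower number from compound 1 to compound 2 (0.33 log units; beyond the scatter). Compound 3 `COc1cccc(OC)c1OCCNCCOc1ccccc1OCc1ccccc1[N+](=O)[O-]` has not yet been measured in this assay. It differs from compound 1 by nitro in place of hydrogen on an aromatic carbon. Among the compounds with values here, no measured step adds a nitro group, so the nearest comparison is the methyl step from compound 1 to compound 2, which was modest but beyond the scatter. That step shows that a single substituent on the outer ring can shift the number, but the substituent and its place differ here, so its direction is not a guide to the nitro change. For compound 3 the expected outcome is therefore a number close to that of compound 1, with a shift of a 1.3-fold higher number from compound 1 to compound 3 (0.12 log units; within the scatter) that stays within or only just beyond the scatter. Compound 3 is estimated at 0.7 nM in this assay, with a likely range from 0.25 nM to 2 nM.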

Compound 3, inhibition constant: 2.51 nM
Compound 3: the middle estimate sits 3.6-fold (0.55 log units) below what was measured; measured number above the stated range.
By their numbers in this assay, from the lowest: compound 2; then compound 1; then compound 3.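

In this assay, the step of a 4.7-fold higher number from compound 1 to compound 3 (0.67 log units; beyond the scatter) shows that this benzyl group does not only tolerate substitution with a lower number: nitro in place of hydrogen, giving the (2-nitrobenzyl)oxy group, moves the number upward, whereas the methyl step a 2.1-fold lower number from compound 1 to compound 2 (0.33 log units; beyond the scatter) moved it downward. The 2-nitrophenyl and 3-methylphenyl groups are also further apart than either is from the unsubstituted phenyl of compound 1, with a 10-fold higher number from compound 2 to compound 3 (1.00 log units; beyond the scatter), so substitution on this ring can move the number in either direction and by a clear margin. Nothing at hand bears on why the nitro group raises the number.

The compounds shown do not separate the effect of the group from that of its place, as the nitro and methyl groups differ in both, and the 2-nitrophenyl and 3-methylphenyl names mark different places on the ring. Going by these compounds, it also remains open whether an amine or a methoxy group at the place taken by the nitro group would raise the number as well, or whether the rise belongs to nitro alone.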